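From 4-methylphenyl to 4-ethylphenyl: one more carbon

The source may report more compounds than this note shows. Statements on the series, on what has been measured and on what is new or still open speak of the compounds shown alone.

Compound 1 `O=C(Nc1ccccc1)C1CCN(C/C=C/c2ccccc2)CC1`: 90900 nM
Compound 2 `Cc1ccc(NC(=O)C2CCN(C/C=C/c3ccccc3)CC2)cc1`: 33900 nM

Within the data shown here, in a functional assay on HepG2 cells (Homo sapiens) for inhibition, read by MTT assay, with a stated time of 72 h (on this read-out higher numbers stand for weaker inhibition and lower numbers for stronger inhibition), compound 2 gives 33900 nM, the lower of the two numbers so far, so it is the stronger inhibitor of this pair. Compound 3 `CCc1ccc(NC(=O)C2CCN(C/C=C/c3ccccc3)CC2)cc1` differs from it by one change, 4-methylphenyl to 4-ethylphenyl: methyl in place of hydrogen on a saturated chain carbon bound to an aromatic carbon. Put another way, a methyl takes the place of a hydrogen on a saturated chain carbon bound to an aromatic carbon.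

Among the measured compounds shown here, only one measured step bears on this: a 2.7-fold lower number from compound 1 to compound 2 (0.43 log units; beyond the scatter). It also brought in a methyl, but on an aromatic carbon, so it is a loose guide. A similar or smaller move in the same direction therefore seems likely. The expected change is a 1.4-fold lower number from compound 2 to compound 3 (0.15 log units; within the scatter), which may not clear the usual scatter. The estimate for compound 3 is 24000 nM, with an expected range of 10000 nM to 55000 nM.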

Compound 3, half-maximal inhibitory concentration: 23300 nM
Beside the measured number, compound 3's estimate is 1.0-fold (0.01 log units) above it; low and high end bracket the measured number.
By their numbers in this assay, from the lowest: compounds 3 and 2 (each within the scatter of the next); then compound 1.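

In this assay the extra carbon of 4-ethylphenyl gives a 1.5-fold lower number from compound 2 to compound 3 (0.16 log units; within the scatter) and so cannot be told apart from repeat-measurement noise at this saturated chain carbon bound to an aromatic carbon. Compared with the hydrogen of compound 1, the ethyl group gives a 3.9-fold lower number from compound 1 to compound 3 (0.59 log units; beyond the scatter) and the methyl of compound 2 gives a 2.7-fold lower number from compound 1 to compound 2 (0.43 log units; beyond the scatter) and so both groups go with a lower number than compound 1, while compound 2 and compound 3 stay within the scatter of each other. Nothing measured here explains why this is so.

As far as these compounds go, whether a longer chain such as propyl would continue this flat stretch or shift the number beyond the scatter remains open. So does the effect of a different kind of group at this place, such as an amine or a carboxylic acid.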